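Amide-nitrogen aryl variation and cytotoxicity in the series

The source may hold more compounds than are shown below. What is called first, only, known or untested is meant among the compounds shown, and "the series" means these compounds.

Compound 1 `COc1ccc2nc(C)cc(OCC(=O)NCc3cc(C)cc(C)c3)c2c1` carries a 3,5-dimethylbenzyl group on the amide-type nitrogen; compound 2 `COc1ccc2nc(C)cc(OCC(=O)Nc3cccc(C)c3)c2c1` carries 3-methylphenyl and compound 3 `COc1ccc2nc(C)cc(OCC(=O)Nc3c(C)cccc3C)c2c1` carries 2,6-dimethylphenyl at the same place. In a toxicity assay on HepG2 cells (Homo sapiens) for inhibition, read by CellTiter-Glo, with a stated time of 48 h (on this read-out higher numbers stand for weaker inhibition and lower numbers for stronger inhibition), compound 1 gives > 100000 nM, which is a limit of the assay and not a number. Compound 2 gives 39800 nM in this assay. Compound 3 also reaches only a limit in this assay, > 100000 nM. Compound 3 thus sits at the top of the measured window, as the limit of > 100000 nM in this assay, at which 2 of the 3 values shown sit, records.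

Compound 4 `COc1ccc2nc(C)cc(OCC(=O)Nc3cc(C)ccc3OC)c2c1` differs from compound 3 in one place: 2-methoxy-5-methylphenyl in place of 2,6-dimethylphenyl on an amide-type nitrogen. Among the compounds with values here, two measured steps bear on this change. The step of an at least 2.5-fold higher number from compound 2 to compound 3 (0.40 log units; beyond the scatter) shows that moving the methyls to both sides of the nitrogen-bearing carbon pushed the value out of range, while a step that the two limits leave unreadable from compound 1 to compound 3 cannot be read. Within the data shown here, compound 4 keeps one methyl on the ring, as compound 2 does, and adds a methoxy group; the only readable precedent for a single methyl is the value of compound 2, 39800 nM.

Compound 4 is therefore expected near 70000 nM in this assay, between 25000 nM and 200000 nM, which means an expected step of an at least 1.4-fold lower number from compound 3 to compound 4 (0.15 log units; that floor lies within the scatter), with a fair chance that only a limit is reported again.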

Compound 4, half-maximal inhibitory concentration: > 100000 nM
Compound 4: no number, only a limit; the forecaster's own chance of this, stated with the estimate: 45%; at least 1.4-fold (0.15 log units) between middle value and limit.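

In this assay, within the data shown here, the single change of methoxy in place of hydrogen on an aromatic carbon gives an at least 2.5-fold higher number from compound 2 to compound 4 (0.40 log units; beyond the scatter), so this position on the aryl ring responds to a substituent even when the methyl of compound 2 stays on the ring. The earlier compounds shown here left open whether one methyl on the ring would be enough for a readable value, and compound 4 shows that it is not enough once the methoxy is present, leaving compound 2 as the only one of the four with a number. The steps from compound 3 and from compound 1 to compound 4 cannot be read, since both ends of each are limits, and the series now sits mostly at one reading: the limit of > 100000 nM in this assay, at which 3 of the 4 values shown sit.

Going by these compounds, how far compound 1, compound 3 and compound 4 lie beyond that limit stays unknown, so no order among them can be given. Also open, on these data alone, is whether an amine or a carboxylic acid in place of the methoxy on the same ring would bring the value back inside the window of this assay.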